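Chloro to methoxy on the benzyl ring

A few compounds are considered here, and "the series" means these few. Any claim that something is new, unique, unknown or untested is made for them only; others in the source may bear on it.

Measured in a functional assay on HepG2 cells (Homo sapiens) for antiproliferative activity, read by MTT assay, with a stated time of 24 h; on this read-out higher numbers stand for weaker inhibition and lower numbers for stronger inhibition:
- compound 1 `Sc1nnc(-c2ccc3c(c2)OCCO3)n1-c1ccccc1`: 60000 nM
- compound 2 `Clc1ccccc1CSc1nnc(-c2ccc3c(c2)OCCO3)n1-c1ccccc1`: 970 nM
- compound 3 `Clc1cccc(CSc2nnc(-c3ccc4c(c3)OCCO4)n2-c2ccccc2)c1`: 2390 nM

Compound 3 stands second highest of the three numbers. The gaps around it are a 25-fold lower number from compound 1 to compound 3 (1.40 log units; beyond the scatter) and a 2.5-fold higher number from compound 2 to compound 3 (0.39 log units; beyond the scatter). Compound 4 `COc1cccc(CSc2nnc(-c3ccc4c(c3)OCCO4)n2-c2ccccc2)c1` carries methoxy in place of chloro on an aromatic carbon, meta to a large group (methoxy in place of chloro on an aromatic carbon). Going by the values given here, no measured step makes this exchange. The large steps of a 62-fold lower number from compound 1 to compound 2 (1.79 log units; beyond the scatter) and a 25-fold lower number from compound 1 to compound 3 (1.40 log units; beyond the scatter) concern the benzyl group on sulfur, which stays in place here. The closest guide is the modest 2.5-fold higher number from compound 2 to compound 3 (0.39 log units; beyond the scatter), which moves the chloro. In this assay, the expected change is no step beyond the scatter, namely a 1.3-fold higher number from compound 3 to compound 4 (0.10 log units; within the scatter). The estimate for compound 4 is 3000 nM, with a range of 1000 nM to 9000 nM.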

Compound 4, half-maximal inhibitory concentration: 35100 nM
Compound 4: the middle estimate sits 12-fold (1.07 log units) below what was measured, and the stated range ends below it.
By their numbers in this assay, from the lowest: compound 2; then compound 3; then compounds 4 and 1 (each within the scatter of the next).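

In this assay, the gain from a benzyl group on sulfur depends on the group at this ring carbon: methoxy in place of chloro gives a large loss (a 15-fold higher number from compound 3 to compound 4 (1.17 log units; beyond the scatter)). The 3-methoxybenzyl group leaves no gain over the free sulfur compound (a 1.7-fold lower number from compound 1 to compound 4 (0.23 log units; within the scatter)), and the 2-chlorobenzyl compound stays far ahead (a 36-fold higher number from compound 2 to compound 4 (1.56 log units; beyond the scatter)). No evidence at hand explains this loss.

On these data alone, whether a fluoro, a trifluoromethyl or a hydroxyl at this carbon would follow chloro or methoxy remains open. So does the effect of methoxy in the 2-chlorobenzyl setting.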